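The source may hold more compounds than are shown below. What is called first, only, known or untested is meant among the compounds shown, and "the series" means these compounds.

Measured so far in a functional assay on MCF7 cells (Homo sapiens) for cytotoxicity, read by MTT assay, with a stated time of 72 h; on this read-out higher numbers stand for weaker inhibition of growth and lower numbers for stronger inhibition of growth:
compound 1, `CCCCOC(=O)Nc1ccc([Se]C#N)cc1`, 20200 nM
compound 2, `CCCCCCOC(=O)Nc1ccc([Se]C#N)cc1`, 30500 nM

Compound 2 gives the highest of the two numbers in this assay; its nearest neighbour is compound 1, with a gap that stays within the scatter. Compound 3 is `CCOC(=O)Nc1ccc([Se]C#N)cc1` and has not yet been tested in this assay. The change from compound 2 to compound 3 is hydrogen in place of butyl on a saturated chain carbon, two bonds along the chain from an oxygen next to a carbonyl group, which cuts the chain back from hexyl to ethyl. Among the compounds with values here, the one measured step that bears on chain length is a 1.5-fold higher number from compound 1 to compound 2 (0.18 log units; within the scatter), where an ethyl was added to the chain and the number did not move beyond the scatter. Read in the opposite direction and somewhat further, that step gives little reason to expect more than a small shift for compound 3 in this assay, if anything toward a lower number. Compound 3 is therefore estimated at 16000 nM in this assay, with a range from 6000 nM to 40000 nM. This estimate amounts to an expected step of a 1.9-fold lower number from compound 2 to compound 3 (0.28 log units; within the scatter).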

Compound 3, concentration for total growth inhibition: 36700 nM
Compound 3: the middle estimate sits 2.3-fold (0.36 log units) below what was measured, and the stated range covers the measured number.
By their numbers in this assay, from the lowest: compounds 1, 2 and 3 (each within the scatter of the next).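

In this assay, cutting the chain from hexyl to ethyl gives a 1.2-fold higher number from compound 2 to compound 3 (0.08 log units; within the scatter), and the comparison with the remaining compound gives a 1.8-fold higher number from compound 1 to compound 3 (0.26 log units; within the scatter). Where the earlier pair covered only a single extension of the chain, the series now spans ethyl to hexyl at this position, and every step among the three compounds stays within the scatter, so no trend with chain length can be read from them and the loss of butyl at this place, two bonds along the chain from an oxygen next to a carbonyl group, carries no measurable consequence in this read-out. No supporting data are available that would account for this flat response.

The compounds shown leave open whether a longer chain, such as decyl, or a chain ending in an amine or a carboxylic acid would move the number beyond the scatter. They also leave open whether the flat response holds when the selenocyanate group or the shared core is changed, and whether it extends beyond this one cell line.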